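Ethoxymethyl swapped for an oxadiazole on the side chain

The source may report more compounds than this note shows. Statements on the series, on what has been measured and on what is new or still open speak of the compounds shown alone.

- compound 1 `COC[C@H]1CCCN(c2ccnc3sc(C(N)=O)c(N)c23)C1` gives 227 ng.h/mL
- compound 2 `CCOCCOC[C@H]1CCCN(c2ccnc3sc(C(N)=O)c(N)c23)C1` gives 2000 ng.h/mL

Both values come from an ADME assay on the whole organism (Rattus norvegicus, strain Fischer 344) for pharmacokinetics, with a stated time of 8 h, at a dose of 3 mg/kg by the oral route; a higher number here means more compound in the circulation at the dose given, a lower number less compound in the circulation. Going by the values given here, compound 2 stands highest of the two, and the only measured step is an 8.8-fold higher number from compound 1 to compound 2 (0.95 log units; beyond the scatter). In that step ethoxymethyl takes the place of hydrogen on a saturated chain carbon bound to an oxygen on a saturated carbon.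

Compound 3 `Cc1noc(COC[C@H]2CCCN(c3ccnc4sc(C(N)=O)c(N)c34)C2)n1` has not been measured. Its difference from compound 2 is 3-methyl-1,2,4-oxadiazol-5-yl in place of ethoxymethyl on a saturated chain carbon bound to an oxygen on a saturated carbon, at that same place: 3-methyl-1,2,4-oxadiazol-5-yl stands in place of ethoxymethyl. Among the compounds with values here, the one measured step therefore bears directly, as the group that leaves is the one whose arrival gave an 8.8-fold higher number from compound 1 to compound 2 (0.95 log units; beyond the scatter). Within the data shown here, no measured compound carries the entering ring, so its own contribution is unknown. Part of the gain is expected to be lost, with the value likely to land between those of the two measured compounds. The expected step is a 2.5-fold lower number from compound 2 to compound 3 (0.40 log units; beyond the scatter), a moderate fall with wide uncertainty. For compound 3 the estimated value is 800 ng.h/mL, with an expected range of 200 ng.h/mL to 2500 ng.h/mL.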

Compound 3, area under the concentration-time curve: 563 ng.h/mL
Beside the measured number, compound 3's estimate is 1.4-fold (0.15 log units) above it, within the range that was stated.
By their numbers in this assay, from the lowest: compound 1; then compound 3; then compound 2.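

In this assay, the place on a saturated chain carbon bound to an oxygen on a saturated carbon now holds two different groups that both stand above the hydrogen, with a 2.5-fold higher number from compound 1 to compound 3 (0.39 log units; beyond the scatter), so the rise is not tied to ethoxymethyl alone. The two groups are not equivalent here: 3-methyl-1,2,4-oxadiazol-5-yl keeps only part of the rise, with a 3.6-fold lower number from compound 2 to compound 3 (0.55 log units; beyond the scatter), and an aromatic ring at this place therefore still serves, though less well than the open ether chain. Nothing on hand explains the size of either step.

Still open, on these data alone, is whether the rise over compound 1 extends to other groups at this place, such as a longer ether chain, an amine or a carboxylic acid, and whether a different five-membered aromatic ring would come closer to compound 2. With this assay as the only read-out shown, how these steps divide between uptake into the circulation and removal from it also remains open.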